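From hex-5-en-1-yl to methyl on the shared core

This account rests on a few compounds, and the source may have more. Where it says the series, first, only, none or still open, it means among the compounds named here.

In a functional assay on T98G cells (Homo sapiens) for inhibition, read by colorimetric assay and MTT assay, with a stated time of 72 h (a higher number here means a weaker inhibitor, a lower number a stronger inhibitor), compound 1 (`C=CCCCCOc1ccccc1-c1cnc(OCCCC=C)n1C`) gives 3000 nM as its half-maximal inhibitory concentration, and compound 2 (`C=CCCCCOc1ccccc1-c1cnc(OCCCCC=C)n1C`) gives 4000 nM on the same read-out. Compound 2 thus has a single measured neighbour and sits level with it, with a 1.3-fold higher number from compound 1 to compound 2 (0.12 log units; within the scatter) for allyl in place of vinyl. Compound 3 (`C=CCCCCOc1ncc(-c2ccccc2OC)n1C`) differs from compound 2 by hydrogen in place of pent-4-en-1-yl on a saturated chain carbon bound to an oxygen on an aromatic ring in one place: hydrogen in place of pent-4-en-1-yl on a saturated chain carbon bound to an oxygen on an aromatic ring. Among the measured compounds shown here, only that one measured step bears on this change, and it is a much smaller edit, so it gives weak guidance. A moderate weakening is expected, and the estimate is a 2.0-fold higher number from compound 2 to compound 3 (0.30 log units; within the scatter) with wide uncertainty. For compound 3 the estimated value is 8000 nM in this assay with an expected range from 2500 nM to 25000 nM around it.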

Compound 3, half-maximal inhibitory concentration: 5000 nM
For compound 3 the middle estimate is 1.6-fold (0.20 log units) above the measured one, within the range that was stated.
By their numbers in this assay, from the lowest: compounds 1, 2 and 3 (each within the scatter of the next).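

Compound 3 carries methoxy where compound 2 carries (hex-5-en-1-yl)oxy, and in this assay this gives a 1.3-fold higher number from compound 2 to compound 3 (0.10 log units; within the scatter) for hydrogen in place of pent-4-en-1-yl on a saturated chain carbon bound to an oxygen on an aromatic ring. The earlier step touched only the end of a chain, whereas this one removes the pent-4-en-1-yl group with its double bond, and the number still stays within the scatter. For this pair, then, the read-out does not separate the long alkenyl chain from plain methyl at this position. Nothing available accounts for this result.

The compounds shown leave open how an amine or a carboxylic acid would read on this oxygen-bound chain. They also leave open whether a chain longer than hex-5-en-1-yl would stay at the same level.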